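A few compounds are considered here, and "the series" means these few. Any claim that something is new, unique, unknown or untested is made for them only; others in the source may bear on it.

Compound 1 `OC[C@H]1O[C@@H](n2cnc3c(NCc4ccc(Cl)cc4)ncnc32)[C@H](O)[C@@H]1O`: > 166000 nM
Compound 2 `OC[C@H]1O[C@@H](n2cnc3c(NCc4ccc(Br)cc4)ncnc32)[C@H](O)[C@@H]1O`: > 166000 nM
Compound 3 `COc1ccc(CNc2ncnc3c2ncn3[C@@H]2O[C@H](CO)[C@@H](O)[C@H]2O)c(OC)c1`: "not determined" (no result reported)

In a functional assay on G-361 cells (Homo sapiens) for antiproliferative activity, with a stated time of 72 h (a higher number here means a weaker inhibitor, a lower number a stronger inhibitor), compound 1 gives > 166000 nM, which is a limit and not a number. Compound 2 gives > 166000 nM, again a limit. Compound 3 has no number to stand on, for its entry reads "not determined" (no result reported). The nearest guide to its place is the limit of > 166000 nM in this assay, at which 2 of the 3 values shown sit.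

Compound 4 `OC[C@H]1O[C@@H](n2cnc3c(NCc4c(F)ccc(F)c4F)ncnc32)[C@H](O)[C@@H]1O` keeps the shared core and swaps the aromatic group: 2,3,6-trifluorophenyl in place of 2,4-dimethoxyphenyl on a saturated chain carbon bound to a nitrogen on an aromatic ring. The only measured step among these compounds is a step that the two limits leave unreadable from compound 1 to compound 2. It is a different change, and its size cannot be read, so it gives no size to carry over. Among the measured compounds shown here, with no value for compound 3 as a starting point, no particular step in this assay can be expected either. The expectation of weak activity rests on compound 2, whose limit is > 166000 nM.

Compound 4 is expected at about 100000 nM, with an estimated range of 15000 nM to 166000 nM, and it may well be reported only as a limit.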

Compound 4, half-maximal inhibitory concentration: > 166000 nM
Compound 4 gave a limit, no number; the forecaster's own chance of this, stated with the estimate: 60%; middle value at least 1.6-fold (0.22 log units) away from the limit.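

In this assay compound 4 gives > 166000 nM, which is a limit and not a number. Among the compounds shown here, compound 1 and compound 2 also stand as limits, so no step to compound 4 can be read. The compounds shown leave open whether changing the aromatic group alters activity at all.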